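A few compounds are considered here, and "the series" means these few. Any claim that something is new, unique, unknown or untested is made for them only; others in the source may bear on it.

Measured so far:

Compound 1, `COc1cc2c(Oc3ccc(NC(=O)c4cc(-c5ccccc5C)ccn4)cc3F)ccnc2cc1OCCCN1CCN(C)CC1`, gives 180 nM in a functional assay on HT-29 cells (Homo sapiens) for cytotoxicity, read by MTT assay, with a stated time of 72 h; a higher number here means a weaker inhibitor, a lower number a stronger inhibitor.

Compound 2, `COc1cc2c(Oc3ccc(NC(=O)c4cc(-c5ccccc5F)ccn4)cc3F)ccnc2cc1OCCCN1CCN(C)CC1`, gives 220 nM in this assay.

Compound 2 sits at the same level as compound 1: the step of a 1.2-fold higher number from compound 1 to compound 2 (0.09 log units; within the scatter) is within the scatter, so the two cannot be told apart on these numbers.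

Compound 3, `COc1ccc(-c2ccnc(C(=O)Nc3ccc(Oc4ccnc5cc(OCCCN6CCN(C)CC6)c(OC)cc45)c(F)c3)c2)cc1`, differs from compound 2 by 4-methoxyphenyl in place of 2-fluorophenyl on an aromatic carbon. Among the measured compounds shown here, the only measured step, a 1.2-fold higher number from compound 1 to compound 2 (0.09 log units; within the scatter), also changes the group at this same position and shows that swapping a methyl for a fluoro there leaves the number essentially unchanged. That step bears on the new change only loosely, since a 4-methoxyphenyl is a different group from either, but it gives no sign that this position drives large shifts. For compound 3 the expected step of a 1.1-fold higher number from compound 2 to compound 3 (0.06 log units; within the scatter) therefore stays within the scatter. Compound 3 is estimated at 250 nM, with a range from 100 nM to 700 nM.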

Compound 3, half-maximal inhibitory concentration: 390 nM
For compound 3 the middle estimate is 1.6-fold (0.19 log units) below the measured one; the measured number falls inside the stated range.
By their numbers in this assay, from the lowest: compounds 1, 2 and 3 (each within the scatter of the next, the first and the last beyond it).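

Putting a 4-methoxyphenyl at this position, opposite the ring nitrogen, gives a 1.8-fold higher number from compound 2 to compound 3 (0.25 log units; within the scatter) in this assay, so this group cannot be told apart from the 2-fluorophenyl on these numbers. Among the compounds shown here, measured against the 2-methylphenyl, the same group gives a 2.2-fold higher number from compound 1 to compound 3 (0.34 log units; beyond the scatter), the first step in this small set to pass beyond the scatter, which shows that the choice of aryl group here can change the number, though only modestly. No measurement at hand accounts for this difference.

The compounds shown cannot separate the effect of the methoxy group from that of its place on the phenyl ring, since the two change together. They also leave open how this position would respond to an amine or a carboxylic acid in place of the phenyl ring.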